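One group exchanged: from compound 2 to compound 4

A few compounds are considered here, and "the series" means these few. Any claim that something is new, unique, unknown or untested is made for them only; others in the source may bear on it.

- compound 1 `CNC(=O)[C@]12C[C@H]1[C@@](C)(c1cc(NC(=O)c3ccc(Cl)cn3)cc(F)c1F)N=C(N)S2` gives 29 10^-6 cm/s
- compound 2 `CN(C)C(=O)[C@]12C[C@H]1[C@@](C)(c1cc(NC(=O)c3ccc(Cl)cn3)cc(F)c1F)N=C(N)S2` gives 40 10^-6 cm/s
- compound 3 `C[C@]1(c2cc(NC(=O)c3ccc(Cl)cn3)cc(F)c2F)N=C(N)S[C@@]2(C#N)C[C@H]21` gives 39 10^-6 cm/s

In an ADME assay on LLC-PK1 cells (Sus scrofa) for permeability (a higher number here means that the compound crosses the layer faster, a lower number that the compound crosses the layer more slowly), compound 2 gives 40 10^-6 cm/s and stands close to both other compounds: a 1.4-fold higher number from compound 1 to compound 2 (0.14 log units; within the scatter) and a 1.0-fold lower number from compound 2 to compound 3 (0.01 log units; within the scatter).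

Compound 4 `C#CCOc1cnc(C(=O)Nc2cc(F)c(F)c([C@@]3(C)N=C(N)S[C@@]4(C(=O)N(C)C)C[C@H]43)c2)cn1` keeps the rest of compound 2 but carries a new group on the carbonyl carbon: 5-(propargyloxy)pyrazin-2-yl in place of 5-chloropyridin-2-yl on a carbonyl carbon. Going by the values given here, no measured step touches that place. Steps such as a 1.3-fold higher number from compound 1 to compound 3 (0.13 log units; within the scatter) therefore only loosely support the expectation of no change beyond the scatter, and the range stays wide. The expected step is a 1.3-fold lower number from compound 2 to compound 4 (0.10 log units; within the scatter). For compound 4 the estimate is 32 10^-6 cm/s, with an expected range from 16 10^-6 cm/s to 55 10^-6 cm/s.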

Compound 4, apparent permeability: 31 10^-6 cm/s
Compound 4: middle estimate off by 1.0-fold (0.01 log units), on the high side, and the stated range covers the measured number.
By their numbers in this assay, from the lowest: compounds 1, 4, 3 and 2 (each within the scatter of the next).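

Compound 4 is the only one shown that alters the group on the carbonyl carbon, as the earlier steps all concern the saturated ring carbon. In this assay the exchange of 5-chloropyridin-2-yl for 5-(propargyloxy)pyrazin-2-yl gives a 1.3-fold lower number from compound 2 to compound 4 (0.11 log units; within the scatter) and so stays within the scatter, although the entering group has more heavy atoms and more hydrogen-bond acceptors. Nothing available explains this result. Still open, going by these compounds, is how an amine or a carboxylic acid on the same ring would read. On these data alone, the separate contributions of the pyrazine ring and the propargyloxy group also remain open.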